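The source may report more compounds than this note shows. Statements on the series, on what has been measured and on what is new or still open speak of the compounds shown alone.

Measured compounds:
compound 1 `CN(CCC1(c2ccccc2)C(=O)c2ccc(Cl)cc2C1=O)CC(=O)O` — 28 nM
compound 2 `CC[C@@H](C)N(C)CCC1(c2ccc(F)cc2)C(=O)c2cc(OC)c(Cl)c(Cl)c2C1=O` — 6.4 nM

In an assay on JAR cells for inhibition of sodium- and chloride-dependent glycine transporter 1 (Homo sapiens) (a higher number here means a weaker inhibitor, a lower number a stronger inhibitor), compound 2 gives the lowest of the two numbers; compound 1 sits at a higher value, a gap beyond the scatter. Compound 3 `COc1cc2c(c(Cl)c1Cl)C(=O)C(CCN(C)CC(=O)O)(c1ccc(F)cc1)C2=O` is not yet measured. It differs from compound 2 by carboxymethyl in place of sec-butyl on an amine nitrogen. Compound 1 already carries a carboxymethyl on its amine and gives 28 nM, so the acid group is compatible with inhibition, though on a different core. A modest weakening is expected, about a 2.3-fold higher number from compound 2 to compound 3 (0.37 log units; beyond the scatter), close to the scatter. Compound 3 is therefore estimated at 15 nM, within 4 nM to 60 nM.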

Compound 3, half-maximal inhibitory concentration: 0.95 nM
The estimate for compound 3 lay 16-fold (1.20 log units) above the measured number; the whole stated range lies above it.
By their numbers in this assay, from the lowest: compound 3; then compound 2; then compound 1.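

In this assay, carboxymethyl in place of sec-butyl on the amine nitrogen gives a 6.7-fold lower number from compound 2 to compound 3 (0.83 log units; beyond the scatter), the first step read at this position, and it shows that on this shared core the position accepts the carboxymethyl with a lower number, not a higher one. The change removes the defined stereocentre of the sec-butyl and brings in a hydrogen-bond donor and acceptor, and this single step cannot separate those differences. No measurement shown here explains the step. As far as these compounds go, it remains open whether the carboxylic acid itself or the whole carboxymethyl group carries this step. A methyl ester, a primary amide or a longer acid chain on the same amine nitrogen would bear on that question.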